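Swapping an Aminophenyl for Methyl on a Shared Core

The source may report more compounds than this note shows. Statements on the series, on what has been measured and on what is new or still open speak of the compounds shown alone.

Measured so far in a functional assay on MDA-MB-435 cells (Homo sapiens) for cytotoxicity, read by MTT assay, with a stated time of 72 h; on this read-out higher numbers stand for weaker inhibition and lower numbers for stronger inhibition:
- compound 1 `Nc1cccc(Nc2c(C(=O)NCc3ccc(F)cc3)nc(Br)c3cccnc23)c1` gives 8000 nM
- compound 2 `CC(C)(C)OC(=O)N1CCN(c2c(C(=O)NCc3ccc(F)cc3)nc(Br)c3cccnc23)CC1` gives 10000 nM
- compound 3 `COc1cccc(CNC(=O)c2nc(Br)c3cccnc3c2N[C@H]2CC[C@H](N)CC2)c1` gives 7000 nM

Compound 1 holds the second highest of the three numbers, and its gaps to compound 3 and compound 2 both lie within the usual scatter, so the three cannot be ranked against each other. Compound 4 `CNc1c(C(=O)NCc2ccc(F)cc2)nc(Br)c2cccnc12` has not yet been measured in this assay. It differs from compound 1 in one place: methyl in place of 3-aminophenyl on a nitrogen on an aromatic ring. A much smaller group thus sits on the nitrogen on the aromatic ring, and the aromatic ring with its donor and acceptor is gone. Going by the values given here, no measured pair shows what such a change does here, so the expectation rests on weak ground. The step is expected to be small, at most a modest weakening beyond the scatter, a 1.9-fold higher number from compound 1 to compound 4 (0.27 log units; within the scatter). For compound 4 the expected value is 15000 nM, with a range from 5000 nM to 45000 nM.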

Compound 4, half-maximal inhibitory concentration: > 20000 nM
Compound 4 was reported as a limit; the forecaster's own chance of this, stated with the estimate: 25%; at least 1.3-fold (0.12 log units) between middle value and limit.
By their numbers in this assay, from the lowest: compounds 3, 1 and 2 (each within the scatter of the next). At a limit, above all of these: compound 4.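

In this assay compound 4 gives > 20000 nM, which is a limit and not a number. Going by these compounds alone, this is the first step that can be read at this nitrogen: methyl in place of 3-aminophenyl gives an at least 2.5-fold higher number from compound 1 to compound 4 (0.39 log units; beyond the scatter), so the group on this nitrogen does affect the read-out, something the three earlier compounds could not show. How large the step really is stays unknown, as the reading ends at a limit: the limit of > 20000 nM in this assay, at which 1 of the 4 values shown sits.

Whether the aromatic ring or its amine accounts for the step remains open, and a plain phenyl on this nitrogen would separate the two. An ethyl or a longer chain there could show whether a group between methyl and 3-aminophenyl in atom count is enough.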